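This account rests on a few compounds, and the source may have more. Where it says the series, first, only, none or still open, it means among the compounds named here.

Measured in an ADME assay on Huh-7 cells (Homo sapiens) for cytotoxicity, read by MTT assay (a higher number here means that more compound is tolerated, a lower number that less compound is tolerated), each value a limit:
- Compound 1 `C[C@H]1CC[C@H](Cn2cnc(=O)c3cc(Oc4ncccc4C(F)(F)F)ccc32)CC1` gives > 10 uM
- Compound 2 `O=c1nc[nH]c2ccc(Oc3ncccc3C(F)(F)F)cc12` gives > 10 uM
- Compound 3 `Cn1cnc(=O)c2cc(Oc3ncccc3C(F)(F)F)ccc21` gives > 10 uM

Compound 3 has only a limit, > 10 uM, so it cannot be ranked within the series. The same holds across the set: the limit of > 10 uM in this assay, at which 3 of the 3 values shown sit.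

Compound 4 `O=c1ncn(CC2CCCCC2)c2ccc(Oc3ncccc3C(F)(F)F)cc12` differs from compound 3 as follows: cyclohexyl in place of hydrogen on a saturated chain carbon bound to an aromatic nitrogen. The same difference reads as methyl to cyclohexylmethyl.

The closest measured step is a step that the two limits leave unreadable from compound 1 to compound 3, which involves a 4-methylcyclohexyl group at the same place. Two further steps concern the aromatic nitrogen: a step that the two limits leave unreadable from compound 2 to compound 3 and a step that the two limits leave unreadable from compound 1 to compound 2. None of them gives a size.

Since compound 1 reports only the limit > 10 uM, no step beyond the scatter is expected in this assay, and no direction can be assigned. The expected step is a step that the limit leaves unreadable from compound 3 to compound 4. For compound 4 the estimate is 15 uM, with an expected range of 7 uM to 40 uM, and the result is likely to be another limit.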

Compound 4, half-maximal toxic concentration: > 10 uM
Compound 4: a limit, no number; the forecaster's own chance of this, stated with the estimate: 85%; the middle value does not contradict the limit.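

Compound 4, like compound 1, compound 2 and compound 3, reports only a limit, so none of its steps to those compounds can be read in this assay: the limit of > 10 uM in this assay, at which 4 of the 4 values shown sit.

The compounds shown leave open what half-maximal toxic concentration any of them has, and whether the substituents on the aromatic nitrogen differ at all in this assay.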